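Imidazoline series: pyridinyl in place of hydroxyphenyl

This account rests on a few compounds, and the source may have more. Where it says the series, first, only, none or still open, it means among the compounds named here.

Compound 1 `CC(Oc1ccccc1-c1ccccc1[N+](=O)[O-])C1=NCCN1`: in a functional assay on CHO cells for agonist activity at Alpha-2B adrenergic receptor (Homo sapiens) (on this read-out higher numbers stand for larger maximal responses and lower numbers for smaller maximal responses), compound 1 gives < 0.3, which is a limit of the assay.
Compound 2 `CC(Oc1ccccc1-c1ccccc1O)C1=NCCN1`: in this assay compound 2 gives < 0.3, again a limit and not a number.
Compound 3 `CC(Nc1ccccc1-c1ccccc1)C1=NCCN1`: in this assay compound 3 gives 0.5.

Compound 2 therefore stands at the floor of what the assay reports, sharing the limit of < 0.3 in this assay, at which 2 of the 3 values shown sit, with compound 1. For the measured compounds named here, the one step that ends at compound 2, a step that the two limits leave unreadable from compound 1 to compound 2, cannot be sized, because both ends are limits. Going by the values given here, compound 3, with an amine linker and an unsubstituted phenyl, is the only member of the series to return a measured number; it differs from compound 2 in two places, so no single step connects them.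

Compound 4 `CC(Oc1ccccc1-c1ccncc1)C1=NCCN1` introduces (pyridin-4-yl in place of 2-hydroxyphenyl on an aromatic carbon). Among the compounds with values here, no measured step bears on this change, and the only step in hand is unreadable, so the expectation rests on compound 2 alone. Compound 2 sits at a limit with < 0.3, and there is nothing in the series to suggest that exchanging the hydroxyphenyl for pyridin-4-yl lifts the maximal response clearly off that floor. Compound 4 is therefore estimated at 0.3, between 0.15 and 0.5. The expected step of a number no lower from compound 2 to compound 4 (the limit leaves the size open) is small and may itself fall below what the assay can read.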

Compound 4, intrinsic activity: the largest response reached, as a fraction of the reference agonist's: < 0.3
Compound 4 gave a limit, no number; the forecaster's own chance of this, stated with the estimate: 50%; the middle value sits exactly at the limit.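

Compound 2 and compound 4 stand at the same limit, not at numbers, so no step can be read between them, and pyridin-4-yl in place of 2-hydroxyphenyl cannot be sized: the limit of < 0.3 in this assay, at which 3 of the 4 values shown sit.

The compounds shown leave open what maximal response compound 1, compound 2 and compound 4 actually reach in this assay, and how far apart they lie.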